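The source may hold more compounds than are shown below. What is called first, only, known or untested is meant among the compounds shown, and "the series" means these compounds.

In an assay on CHO cells for displacement of a labelled ligand from adenosine receptor A3 (Homo sapiens), read by scintillation counting, with a stated time of 3 h (on this read-out higher numbers stand for weaker inhibition and lower numbers for stronger inhibition), compound 2 `Cc1ccc(C(=O)Nc2nc(Cl)c3cn(CC(C)(C)C)nc3n2)cc1` gives 5000 nM, the lower of the two numbers shown. Compound 1 `Cc1ccc(C(=O)Nc2nc(Cl)c3cn(C)nc3n2)cc1` gives 13500 nM in this assay, and the move from compound 1 to compound 2 brought a 2.7-fold lower number from compound 1 to compound 2 (0.43 log units; beyond the scatter). Compound 3 `Cn1cc2c(Cl)nc(N)nc2n1` shows only a limit in this assay, > 100000 nM, not a number. Compound 4 `CC(C)(C)Cn1cc2c(Cl)nc(NC(=O)c3ccc(C(F)(F)F)cc3)nc2n1` carries trifluoromethyl in place of methyl on an aromatic carbon. Going by the values given here, no measured step touches that ring position: the one step seen concerns the chain carbon bound to an aromatic nitrogen, so it gives no guide to this change. A step from compound 2 to compound 4 of a 1.3-fold lower number from compound 2 to compound 4 (0.10 log units; within the scatter) is therefore expected, within the scatter. Compound 4 is estimated at 4000 nM in this assay, with a range from 1500 nM to 12000 nM.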

Compound 4, inhibition constant: 6600 nM
The estimate for compound 4 lay 1.7-fold (0.22 log units) below the measured number, within the range that was stated.
By their numbers in this assay, from the lowest: compounds 2 and 4 (each within the scatter of the next); then compound 1. At a limit, above all of these: compound 3.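

Going by these compounds alone, compound 1 and compound 2 both carry methyl on this aromatic carbon, so the earlier compounds said nothing about replacing it. In this assay trifluoromethyl in place of methyl brought a 1.3-fold higher number from compound 2 to compound 4 (0.12 log units; within the scatter) and so the two groups cannot be told apart at this position. Nothing measured here offers a cause for this result.

As far as these compounds go, whether an amine or a carboxylic acid at this position would give a different number stays open. Also open, from the compounds shown here alone, is whether the same swap would read alike on the core of compound 1.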